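Dropping One Chloro Group on Two Related Cores

This account rests on a few compounds, and the source may have more. Where it says the series, first, only, none or still open, it means among the compounds named here.

The series consists of four compounds built around two closely related cores. Compound 1 `ClCc1ccccc1Cn1cnc2c(Cl)nc(Cl)nc21` and compound 2 `ClCc1ccccc1Cn1cnc2c(Cl)ncnc21` share one core; compound 3 `ClCc1ccc(Cn2cnc3nc(Cl)nc(Cl)c32)cc1` and compound 4 `ClCc1ccc(Cn2cnc3ncnc(Cl)c32)cc1` share the other. The difference between the two cores is not broken down here.

In a functional assay on NCI/ADR-RES cells (Homo sapiens) for cytotoxicity, read by sulforhodamine B assay, with a stated time of 48 h (on this read-out lower numbers stand for stronger inhibition of growth and higher numbers for weaker inhibition of growth), compound 1 gives 1510 nM. Compound 2 differs from compound 1 by hydrogen in place of chloro on an aromatic carbon, and in this assay compound 2 gives 2180 nM. The step is a 1.4-fold higher number from compound 1 to compound 2 (0.16 log units; within the scatter). Compound 3, measured in this assay, gives 2080 nM; its value and those of compound 1 and compound 2 all lie within the usual scatter of one another, so no order among the three can be stated.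

Compound 4 differs from compound 3 by hydrogen in place of chloro on an aromatic carbon, the same change that separates compound 2 from compound 1, made at the same kind of position on the second core. Because the same change gave a 1.4-fold higher number from compound 1 to compound 2 (0.16 log units; within the scatter), a step of similar size is expected on the second core. The expected step in this assay is a 1.4-fold higher number from compound 3 to compound 4 (0.14 log units; within the scatter). For compound 4 the estimate in this assay is 2900 nM, with a range from 1500 nM to 6000 nM. Whether the second core answers the change in the same way is what the measurement will show.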

Compound 4, concentration for 50% growth inhibition: 1810 nM
Estimate against measurement, compound 4: 1.6-fold (0.20 log units) above; the range from low to high includes it.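

In this assay, the exchange of chloro for hydrogen on the second core, at the aromatic carbon between two ring nitrogen atoms, gives a 1.1-fold lower number from compound 3 to compound 4 (0.06 log units; within the scatter). Set beside the same exchange on the first core, this step shows no difference that the measurements can resolve, so the change carries from one core to the other without a readable shift in this assay: the same change on two cores in this assay, a 1.4-fold higher number (0.16 log units; within the scatter) from compound 1 to compound 2 and a 1.1-fold lower number (0.06 log units; within the scatter) from compound 3 to compound 4, 1.7-fold (0.22 log units) apart, within the scatter of two such steps This does not show that the two cores answer the change identically, nor that the chloro group at this place is without any effect, as neither step stands clear of the scatter and two pairs of compounds make no rule for a wider series.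

The compounds shown leave open what an amine, a methoxy group or a thiol would do at this place, since only chloro and hydrogen appear there, and whether any such group would give a step beyond the scatter. They also leave open what would follow if the remaining chloro group on the six-membered aromatic ring gave way to an amine, and whether the two cores would still match under such a change.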